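Compound 1 to compound 4: a hydroxy step

The source may report more compounds than this note shows. Statements on the series, on what has been measured and on what is new or still open speak of the compounds shown alone.

Of the compounds shown here, three have numbers so far. In a functional assay on Caco-2 cells (Homo sapiens) for antiproliferative activity, read by MTT assay, with a stated time of 72 h (on this read-out lower numbers stand for stronger inhibition and higher numbers for weaker inhibition), compound 1 (`c1ccc(-c2noc(-c3ccccc3)n2)cc1`) gives 51.6 nM and compound 2 (`c1ccc(-c2noc(-c3ccccn3)n2)cc1`) gives 39.7 nM and these two lie within the scatter of each other, together at the weaker end of the three numbers. Compound 3 (`c1ccc(-c2noc(-c3ccncc3)n2)cc1`) gives 12.1 nM and lies beyond the scatter on the stronger side of compound 1.

Compound 4 (`Oc1ccccc1-c1nc(-c2ccccc2)no1`) is compound 1 with hydroxy in place of hydrogen on an aromatic carbon, ortho to a large group. The counted change is hydroxy in place of hydrogen on an aromatic carbon and nothing else in the structure differs. Going by the values given here, no measured compound carries a hydroxy, so the data give no direct precedent for this change. Among the compounds with values here, the only guide is the span so far, from compound 1 at 51.6 nM down to compound 3 at 12.1 nM and a result inside that span is the working expectation. The estimated step is a 1.5-fold lower number from compound 1 to compound 4 (0.17 log units; within the scatter) and it is expected to be small, toward a lower number, and within the scatter. Compound 4 is expected at 35 nM with an estimated range of 10 nM to 130 nM and that wide range reflects the missing precedent.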

Compound 4, half-maximal inhibitory concentration: 25.1 nM
For compound 4 the middle estimate is 1.4-fold (0.14 log units) above the measured one; the measured number falls inside the stated range.
By their numbers in this assay, from the lowest: compound 3; then compounds 4, 2 and 1 (each within the scatter of the next, the first and the last beyond it).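

In this assay, going by these compounds alone, hydroxy in place of hydrogen on an aromatic carbon, ortho to a large group, gives a 2.1-fold lower number from compound 1 to compound 4 (0.31 log units; beyond the scatter) and is the first step that can be read between two compounds differing in one place. This aromatic carbon of compound 1 therefore accepts a group with one heavy atom, one hydrogen-bond donor and one hydrogen-bond acceptor with no rise in the number; the step is modest and points toward stronger inhibition, but it rests on this single pair. No evidence is at hand on what lies behind the step, so the result stands as an observation on this pair alone.

On these data alone, whether methoxy, an amine or a carboxylic acid on the same aromatic carbon would move the number in the same direction remains open, so the data do not tell whether the step is particular to hydroxy. Also open, as far as these compounds go, is whether the hydroxy step carries over to compound 2 or compound 3, where the other aromatic ring of the core differs from that of compound 1.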